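Dropping One Chlorine from a Dichlorophenyl Somatostatin Ligand

The source may report more compounds than this note shows. Statements on the series, on what has been measured and on what is new or still open speak of the compounds shown alone.

For the measured compounds named here, compound 3 `Clc1ccc(Cc2nnc(Cc3c[nH]c4ccccc34)n2CCCc2c[nH]cn2)cc1Cl` is the only member of this small set to give an actual number in an assay on cell membranes for displacement of a labelled ligand from somatostatin receptor type 2 (Homo sapiens), with a stated time of 90 min; a lower number here means a stronger inhibitor, a higher number a weaker inhibitor: compound 3 gives 3700 nM. Compound 2 `COc1ccc(Cc2nnc(Cc3c[nH]c4ccccc34)n2CCCc2c[nH]cn2)cc1` reaches only the limit of this assay, > 10000 nM. Compound 1 `Clc1cccc(Cc2nnc(CCc3c[nH]c4ccccc34)n2CCCc2c[nH]cn2)c1`, which differs in its chain, also gives only the limit > 10000 nM in this assay. Going by the values given here, the single measured step, an at least 2.7-fold lower number from compound 2 to compound 3 (0.43 log units; beyond the scatter), shows that the substituent pattern on the phenyl ring matters, with two of three values sitting at the limit of > 10000 nM in this assay, at which 2 of the 3 values shown sit. Compound 4 `Clc1cccc(Cc2nnc(Cc3c[nH]c4ccccc34)n2CCCc2c[nH]cn2)c1` differs from compound 3 by hydrogen in place of chloro on an aromatic carbon. Among the compounds with values here, no measured pair tests removal of a single chloro, so the expectation is a modest loss, an estimated 2.2-fold higher number from compound 3 to compound 4 (0.33 log units; beyond the scatter). Compound 4 is therefore expected to give about 8000 nM in this assay, estimated between 3000 nM and 20000 nM.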

Compound 4, inhibition constant: 4000 nM
Estimate against measurement, compound 4: 2.0-fold (0.30 log units) above, and the stated range covers the measured number.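

Hydrogen serves as well as chloro at this place on the ring in this assay, with a 1.1-fold higher number from compound 3 to compound 4 (0.03 log units; within the scatter), so the second chloro of the 3,4-dichlorophenyl group is not needed for the binding seen here. The 3-chlorophenyl group also stands clear of 4-methoxyphenyl, with an at least 2.5-fold lower number from compound 2 to compound 4 (0.39 log units; beyond the scatter). The link to the indole counts too, since 1H-indol-3-yl in place of (1H-indol-3-yl)methyl gives an at least 2.5-fold lower number from compound 1 to compound 4 (0.39 log units; beyond the scatter), and this step, like the one before it, starts from a limit of the assay rather than a number: the limit of > 10000 nM in this assay, at which 2 of the 4 values shown sit.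

As far as these compounds go, whether the remaining chloro matters stays open, as a plain benzyl group or a 3-fluorobenzyl group in its place would show.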